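Swapping diethylamino for ethoxy on a coumarin-like hydrazide core

This account rests on a few compounds, and the source may have more. Where it says the series, first, only, none or still open, it means among the compounds named here.

Measured so far:
compound 1 `CCOc1ccc2cc(C(=O)NCCO)c(=O)oc2c1` — > 100000 nM
compound 2 `CCN(CC)c1ccc2cc(C(=O)NN)c(=O)oc2c1` — 5480 nM

Among the compounds with values here, in a functional assay on HeLa cells (Homo sapiens) for cytotoxicity, read by MTT assay, with a stated time of 72 h (a higher number here means a weaker inhibitor, a lower number a stronger inhibitor), compound 2 gives 5480 nM, the only measured number here. For compound 1 the assay reports only a limit, > 100000 nM, not a number; this is the limit of > 100000 nM in this assay, at which 1 of the 2 values shown sits. Compound 3 `CCOc1ccc2cc(C(=O)NN)c(=O)oc2c1` is the untested partner of compound 2, differing by one change: ethoxy in place of diethylamino on an aromatic carbon. Within the data shown here, no comparable measured step exists, so the size of the step must be judged from the limit for compound 1 alone. Compound 3 is expected to be a weaker inhibitor than compound 2, by a step of about a 7.3-fold higher number from compound 2 to compound 3 (0.86 log units; beyond the scatter) in this assay. The estimate for compound 3 is 40000 nM, with a range from 8000 nM to 200000 nM.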

Compound 3, half-maximal inhibitory concentration: 38300 nM
The estimate for compound 3 lay 1.0-fold (0.02 log units) above the measured number, and the stated range covers the measured number.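

In this assay, ethoxy in place of diethylamino on the aromatic carbon gives a 7.0-fold higher number from compound 2 to compound 3 (0.84 log units; beyond the scatter), so this position changes the reading when the amide-type nitrogen carries amino. With ethoxy held fixed, amino in place of 2-hydroxyethyl on that nitrogen gives an at least 2.6-fold lower number from compound 1 to compound 3 (0.41 log units; beyond the scatter), so a second site on the shared core matters too. That second step is only a bound, since compound 1 stands at a limit: the limit of > 100000 nM in this assay, at which 1 of the 3 values shown sits.

Still open, going by these compounds, is whether a smaller amine such as dimethylamino on this carbon would match diethylamino. It is also unclear whether a longer chain such as butoxy would read like ethoxy.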